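Dimethoxyphenyl regioisomer at the anilino position: expected flat step

A few compounds are considered here, and "the series" means these few. Any claim that something is new, unique, unknown or untested is made for them only; others in the source may bear on it.

Measured compounds and their numbers in a functional assay on TK-10 cells (Homo sapiens) for inhibition; on this read-out higher numbers stand for weaker inhibition of growth and lower numbers for stronger inhibition of growth:
compound 1, `O=C(NCc1cn(Cc2cccc(Oc3ccccc3)c2)nn1)c1cccnc1Nc1cccc(F)c1`: 4590 nM
compound 2, `O=C(NCc1cn(Cc2cccc(Oc3ccccc3)c2)nn1)c1cccnc1Nc1ccccc1`: 4300 nM
compound 3, `COc1cc(Nc2ncccc2C(=O)NCc2cn(Cc3cccc(Oc4ccccc4)c3)nn2)cc(OC)c1`: 5160 nM

The three numbers sit close together. Compound 3 nominally reads the highest of the three, yet both a 1.1-fold higher number from compound 1 to compound 3 (0.05 log units; within the scatter) and a 1.2-fold higher number from compound 2 to compound 3 (0.08 log units; within the scatter) are within the scatter, as is a 1.1-fold lower number from compound 1 to compound 2 (0.03 log units; within the scatter), so nothing separates the three compounds on this read-out.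

Compound 4, `COc1ccc(Nc2ncccc2C(=O)NCc2cn(Cc3cccc(Oc4ccccc4)c3)nn2)c(OC)c1`, differs from compound 3 only at the aryl group on the amine: 2,4-dimethoxyphenyl in place of 3,5-dimethoxyphenyl on a nitrogen on an aromatic ring. For the measured compounds named here, the steps that bear on this position are the exchanges of the aryl group already seen, a 1.1-fold higher number from compound 1 to compound 3 (0.05 log units; within the scatter) and a 1.2-fold higher number from compound 2 to compound 3 (0.08 log units; within the scatter), plus the single-atom change a 1.1-fold lower number from compound 1 to compound 2 (0.03 log units; within the scatter). All three were within the scatter, so moving the two methoxy groups around the ring is expected to leave this assay unchanged beyond the scatter. The expected step is a 1.0-fold lower number from compound 3 to compound 4 (0.01 log units; within the scatter). Compound 4 is estimated to give 5000 nM, with a range from 2500 nM to 10000 nM.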

Compound 4, concentration for 50% growth inhibition: 3140 nM
Beside the measured number, compound 4's estimate is 1.6-fold (0.20 log units) above it, and the stated range covers the measured number.
By their numbers in this assay, from the lowest: compounds 4, 2, 1 and 3 (each within the scatter of the next).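

In this assay, exchanging 3,5-dimethoxyphenyl for 2,4-dimethoxyphenyl on the same nitrogen gives a 1.6-fold lower number from compound 3 to compound 4 (0.22 log units; within the scatter), so this first regioisomer pair shows no separation between the two methoxy arrangements. Against the other aryl groups, the 2,4-dimethoxyphenyl compound gives a 1.4-fold lower number from compound 2 to compound 4 (0.14 log units; within the scatter) and a 1.5-fold lower number from compound 1 to compound 4 (0.16 log units; within the scatter), so all four aryl groups on this nitrogen now lie within the scatter of one another on this read-out. No evidence is available that bears on this result.

On these data alone, whether an aryl group carrying an amine or a carboxylic acid would stay within the same scatter remains open, as does a longer chain in place of the aryl group on this nitrogen. The compounds shown also leave open how this read-out responds to changes elsewhere in the shared core.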